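The compounds below may be only part of what the source reports. "The series", "measured", "known", "first", "only" and "open" are said of these compounds alone.

Measured so far in an ADME assay on MT4 cells (Homo sapiens) for cytotoxicity, read by MTT assay; on this read-out lower numbers stand for higher toxicity in this test and higher numbers for lower toxicity in this test:
- compound 1 `O=C(CSc1nncnc1-c1cccc2ccccc12)Nc1ccc(Cl)cc1Cl`: 254000 nM
- compound 2 `CC(=O)c1ccc(NC(=O)CSc2nncnc2-c2cccc3ccccc23)c(Br)c1`: 133000 nM

In this assay, compound 2 gives 133000 nM, and the data do not separate it from compound 1. Among the compounds with values here, the only measured step is a 1.9-fold lower number from compound 1 to compound 2 (0.28 log units; within the scatter), so the two compounds stand level within the scatter.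

The next compound, compound 3 `Cc1ccccc1NC(=O)CSc1nncnc1-c1cccc2ccccc12`, keeps the shared core and has 2-methylphenyl in place of 4-acetyl-2-bromophenyl on an amide-type nitrogen. The measured step bears directly on this change, since it too exchanges the group at that amide-type nitrogen. That exchange, a 1.9-fold lower number from compound 1 to compound 2 (0.28 log units; within the scatter), did not move the number beyond the scatter. Within the data shown here, it is a single step, however, and no measured compound carries 2-methylphenyl, so the evidence is thin. No step beyond the scatter is therefore expected in this assay, and no direction can be firmly expected. The expected change is a 1.4-fold higher number from compound 2 to compound 3 (0.13 log units; within the scatter). For compound 3 the estimated value is 180000 nM, with an expected range of 70000 nM to 400000 nM.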

Compound 3, half-maximal cytotoxic concentration: 158000 nM
Compound 3: the middle estimate sits 1.1-fold (0.06 log units) above what was measured, and the stated range covers the measured number.
By their numbers in this assay, from the lowest: compounds 2, 3 and 1 (each within the scatter of the next).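

In this assay, the amide-type nitrogen now has a third substituent: 2-methylphenyl in place of 4-acetyl-2-bromophenyl gives a 1.2-fold higher number from compound 2 to compound 3 (0.07 log units; within the scatter), and 2-methylphenyl in place of 2,4-dichlorophenyl gives a 1.6-fold lower number from compound 1 to compound 3 (0.21 log units; within the scatter). The earlier pair compared only halogen-bearing groups, whereas the entering 2-methylphenyl holds carbon atoms alone, with no bromine, chlorine, oxygen or hydrogen-bond acceptor, and all three compounds still stand level within the scatter at this position. No evidence is at hand that would explain why these three groups read alike.

The compounds shown leave open whether this level reading would hold for a different kind of group on the amide-type nitrogen, such as a phenyl ring carrying a carboxylic acid or an amine, or a cyclohexyl ring in place of the aromatic ring. They also leave open what a change elsewhere in the molecule would do, since all three compounds share the same core and differ only at this one nitrogen.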